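A few compounds are considered here, and "the series" means these few. Any claim that something is new, unique, unknown or untested is made for them only; others in the source may bear on it.

Compound 1: `COc1ccc2c(c1)c(/C=N\NC(=O)c1c[nH]c3ccc(Br)cc13)cn2Cc1ccc(Cl)cc1` gives 57000 nM.
Compound 2: `O=C(N/N=C\c1cn(Cc2ccc(Cl)cc2)c2cc(F)ccc12)c1c[nH]c2ccccc12` gives 18600 nM.

Of the compounds shown here, two have been measured in a functional assay on DU-145 cells (Homo sapiens) for cytotoxicity; a higher number here means a weaker inhibitor, a lower number a stronger inhibitor. Compound 1, `COc1ccc2c(c1)c(/C=N\NC(=O)c1c[nH]c3ccc(Br)cc13)cn2Cc1ccc(Cl)cc1`, gives 57000 nM in this assay. Compound 2, `O=C(N/N=C\c1cn(Cc2ccc(Cl)cc2)c2cc(F)ccc12)c1c[nH]c2ccccc12`, gives 18600 nM in this assay and stands lowest of the two numbers; its nearest neighbour is compound 1, whose number is higher by a gap that lies beyond the scatter. The two compounds differ in more than one place, so their two values can only be set side by side, not read as a single step.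

Compound 3, `Cn1cc(C(=O)N/N=C\c2cn(Cc3ccc(Cl)cc3)c3cc(F)ccc23)c2ccccc21`, has not yet been measured. It differs from compound 2 in one place: methyl in place of hydrogen on an aromatic nitrogen. Going by the values given here, no measured pair in this set shows what such a change does in this assay, so there is no step to lean on. The change is small and adds no donor or acceptor; she expects the step from compound 2 to compound 3 to be modest, with the number estimated to drift somewhat upward, and a result within the scatter would not surprise her. The step she expects is a 1.4-fold higher number from compound 2 to compound 3 (0.15 log units; within the scatter). Compound 3 is estimated at 26000 nM, within a range from 8000 nM to 85000 nM.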

Compound 3, half-maximal inhibitory concentration: 84200 nM
Beside the measured number, compound 3's estimate is 3.2-fold (0.51 log units) below it; the range from low to high includes it.
By their numbers in this assay, from the lowest: compound 2; then compounds 1 and 3 (each within the scatter of the next).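

In this assay, going by these compounds alone, the change from 1H-indol-3-yl to 1-methyl-1H-indol-3-yl gives a 4.5-fold higher number from compound 2 to compound 3 (0.66 log units; beyond the scatter) as the first step in this set that can be read as a single change. Within the data shown here, it shows that this aromatic nitrogen of the five-membered aromatic ring is a place where a small edit registers: one methyl, a single heavy atom with no hydrogen-bond donors or acceptors, moves the number beyond the scatter and towards a weaker inhibitor, something the side-by-side values of the earlier compounds could not show. Nothing available here explains the size or direction of this step.

The compounds shown leave open whether an ethyl group, a longer chain or an acetyl group on the same nitrogen would carry the number further up or bring it back. They also leave open whether methyl in place of hydrogen at this nitrogen would give a step of similar size in compound 1, which carries the same hydrogen on a differently substituted core.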